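A few compounds are considered here, and "the series" means these few. Any claim that something is new, unique, unknown or untested is made for them only; others in the source may bear on it.

Working notes on the series. In a functional assay on the whole organism for antagonist activity, with Mus musculus as the target (a higher number here means that more compound is needed for the effect, a lower number that less compound is needed), compound 1 `COc1cc(N)c(Cl)cc1NC(=O)C1CCN(Cc2cccc(C)c2)CC1` gives 2.4 mg/kg, the lowest of the two numbers in hand. Compound 2 `COc1cc(N)c(Cl)cc1NC(=O)C1CCN(Cc2ccsc2)CC1` gives 3.4 mg/kg in this assay. Compound 3 `COc1cccc(CN2CCC(C(=O)Nc3cc(Cl)c(N)cc3OC)CC2)c1` reaches only a limit in this assay, > 4 mg/kg. The steps between these three are all small: a 1.4-fold higher number from compound 1 to compound 2 (0.15 log units; within the scatter); an at least 1.6-fold higher number from compound 1 to compound 3 (0.22 log units; that floor lies within the scatter); an at least 1.1-fold higher number from compound 2 to compound 3 (0.07 log units; that floor lies within the scatter). One of the three values sits at the limit of > 4 mg/kg in this assay, at which 1 of the 3 values shown sits.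

Compound 4 `COc1cc(N)c(Cl)cc1NC(=O)C1CCN(CC2CCC2)CC1` is not yet measured in this assay. It differs from compound 1 in one place: cyclobutyl in place of 3-methylphenyl on a saturated chain carbon bound to an amine nitrogen in a ring. The step from compound 1 to compound 2 changes the same position and stays within the scatter, and the step from compound 1 to compound 3 has a floor that also lies within the scatter. Among the measured compounds shown here, no measured compound carries a non-aromatic ring at this position, so the comparison is indirect. The expected outcome is a small shift toward a higher number, within the scatter. Compound 4 is therefore expected to give about 3.5 mg/kg in this assay, with a range from 1.8 mg/kg to 8 mg/kg. The step expected is a 1.5-fold higher number from compound 1 to compound 4 (0.16 log units; within the scatter).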

Compound 4, dose for half-maximal effect: > 10 mg/kg
Compound 4: no number, only a limit; the forecaster's own chance of this, stated with the estimate: 30%; middle value at least 2.8-fold (0.45 log units) away from the limit.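

Compound 4 yields a limit, not a number: the limit of > 10 mg/kg in this assay, at which 1 of the 4 values shown sits. Among the compounds shown here, with cyclobutyl at this position there is an at least 4.1-fold higher number from compound 1 to compound 4 (0.61 log units; beyond the scatter), and there is also an at least 2.9-fold higher number from compound 2 to compound 4 (0.46 log units; beyond the scatter); these are the first steps here that lie beyond the scatter, and they come with the first non-aromatic ring on the saturated chain carbon bound to an amine nitrogen in a ring. No step can be read for compound 3 and compound 4, as each of the two values is a limit.

The compounds shown do not separate the loss of the aromatic ring from the drop in heavy atoms, since cyclobutyl differs from 3-methylphenyl in both. Cyclohexyl at this place would address that question, and the size of the step to compound 4 stays unknown while its value remains a limit.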